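The compounds below may be only part of what the source reports. "The series", "measured", "known", "first", "only" and "open" are said of these compounds alone.

Working notes on the series. Among the measured compounds shown here, compound 2 `Cc1ccc(OCC(=O)N(Cc2cccs2)c2ccnn2C)cc1` holds the lowest number of the two so far recorded in an assay on HEK293 cells for agonist activity at transient receptor potential cation channel subfamily M member 8 (Homo sapiens), read by fluorescence and calcium flux, with a stated time of 15 min; a lower number here means that less compound is needed, a higher number that more compound is needed for the effect: compound 2 gives 422 nM. For the measured compounds named here, its only neighbour on file is compound 1 `Cc1ccc(OCC(=O)N(Cc2cccs2)C2CCCCC2)cc1`, which carries the cyclohexyl group on the amide-type nitrogen; in this assay compound 1 gives 40000 nM. Going by the values given here, the single step between them, a 95-fold lower number from compound 1 to compound 2 (1.98 log units; beyond the scatter), is the only measured change and is large.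

Compound 3 `Cc1ccc(OCC(=O)N(Cc2cccs2)C2COC2)cc1` differs from compound 2 by oxetan-3-yl in place of 1-methyl-1H-pyrazol-5-yl on an amide-type nitrogen. The change undoes the aromatic ring that compound 2 carries at this nitrogen and puts a saturated ring there, which is the direction of compound 1 rather than of compound 2. The step that bears on it is a 95-fold lower number from compound 1 to compound 2 (1.98 log units; beyond the scatter): moving from a saturated ring to the aromatic one at this position brought a large fall, so the reverse kind of change is expected to bring a rise in this assay. Since oxetan-3-yl is not cyclohexyl, the full reversal is not assumed; for compound 3 the expected step is a 19-fold higher number from compound 2 to compound 3 (1.28 log units; beyond the scatter), upward and beyond the scatter, giving an estimate of 8000 nM with a range from 1500 nM to 40000 nM.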

Compound 3, half-maximal effective concentration: 23000 nM
For compound 3 the middle estimate is 2.9-fold (0.46 log units) below the measured one; the measured number falls inside the stated range.
By their numbers in this assay, from the lowest: compound 2; then compounds 3 and 1 (each within the scatter of the next).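

With oxetan-3-yl in place of 1-methyl-1H-pyrazol-5-yl on the amide-type nitrogen, this assay shows a 55-fold higher number from compound 2 to compound 3 (1.74 log units; beyond the scatter) and thereby places a second non-aromatic ring at the high end of the series. A hetero atom in a non-aromatic ring at this position is therefore not enough to keep the low number of compound 2. Oxetan-3-yl in place of cyclohexyl gives a 1.7-fold lower number from compound 1 to compound 3 (0.24 log units; within the scatter) and so leaves these two non-aromatic rings indistinguishable in this read-out, while among the three compounds only the aromatic 1-methyl-1H-pyrazol-5-yl gives a low number, with no compound going against this, though the pattern rests on that single aromatic group.

As far as these compounds go, it remains open whether the low number follows from an aromatic ring on this nitrogen in general or from 1-methyl-1H-pyrazol-5-yl in particular, and a phenyl ring or an unmethylated pyrazole would bear on that. From the compounds shown here alone, how an open-chain group such as a longer alkyl chain or an amine would read at this position also stays open. Nothing on file accounts for the gap between the aromatic and the non-aromatic groups.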